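The source may hold more compounds than are shown below. What is called first, only, known or untested is meant among the compounds shown, and "the series" means these compounds.

Measured so far in a functional assay on U-87MG ATCC cells (Homo sapiens) for inhibition; on this read-out lower numbers stand for stronger inhibition and higher numbers for weaker inhibition:
- compound 1 `COc1cc(/C=C/C(=O)c2cccc(NC(=O)c3cccs3)c2)ccc1O` gives 14.7 ug/mL
- compound 2 `COc1cc(/C=C/C(=O)c2cccc(NC(=O)c3ccc(Cl)c(Cl)c3)c2)ccc1O` gives 29.5 ug/mL
- compound 3 `COc1cc(/C=C/C(=O)c2cccc(NC(=O)C(C)C)c2)ccc1O` gives 8.31 ug/mL

Compound 3 sits at the low end of these numbers, but it shares that end with compound 1. The measured steps show a 1.8-fold lower number from compound 1 to compound 3 (0.25 log units; within the scatter) and a 3.5-fold lower number from compound 2 to compound 3 (0.55 log units; beyond the scatter), so only compound 2 stands apart from compound 3.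

Next comes compound 4 `COc1cc(/C=C/C(=O)c2cccc(NC(C)=O)c2)ccc1O`, with the change (methyl in place of isopropyl on a carbonyl carbon), that is, methyl in place of isopropyl on a carbonyl carbon. Within the data shown here, no measured compound carries this methyl, so the estimate is an extrapolation. All three measured steps change the group at this same carbonyl carbon. Besides the two above, there is a 2.0-fold higher number from compound 1 to compound 2 (0.30 log units; within the scatter). Among the measured compounds shown here, only the step that joins the isopropyl and 3,4-dichlorophenyl groups leaves the scatter, and it stays modest. Compound 4 carries neither a ring nor a larger group here, so it resembles compound 3 most closely. No step beyond the scatter is therefore expected in this assay, and no direction can be called with confidence. The expected step is a 1.2-fold higher number from compound 3 to compound 4 (0.08 log units; within the scatter). For compound 4 the estimated value is 10 ug/mL, with an expected range from 4.5 ug/mL to 22 ug/mL.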

Compound 4, half-maximal inhibitory concentration: > 50 ug/mL
Compound 4: no number, only a limit (the forecaster's own chance of this, stated with the estimate: 5%); at least 5.0-fold (0.69 log units) between middle value and limit.
By their numbers in this assay, from the lowest: compounds 3, 1 and 2 (each within the scatter of the next, the first and the last beyond it). At a limit, above all of these: compound 4.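

In this assay compound 4 gives no number, only a limit: the limit of > 50 ug/mL in this assay, at which 1 of the 4 values shown sits. Among these compounds, the position is more sensitive than the earlier compounds suggested, since replacing isopropyl with methyl on this carbonyl carbon gives an at least 6.0-fold higher number from compound 3 to compound 4 (0.77 log units; beyond the scatter), and the same methyl against thiophen-2-yl gives an at least 3.4-fold higher number from compound 1 to compound 4 (0.53 log units; beyond the scatter), whereas thiophen-2-yl and isopropyl stayed within the scatter of each other. Group size does not order the series. Methyl and 3,4-dichlorophenyl both lie at the weak end and isopropyl at the strong end, and an at least 1.6-fold higher number from compound 2 to compound 4 (0.22 log units; that floor lies within the scatter) leaves compound 4 unseparated from compound 2 at that floor.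

Going by these compounds, with only a limit for compound 4, the true size of all three steps stays unknown, and a single methyl compound cannot show whether the loss belongs to this group alone or to small groups in general. On these data alone, whether an ethyl, cyclopropyl or tert-butyl group on this carbonyl carbon would hold the number near that of compound 3, at 8.31 ug/mL, remains open, as does the effect of an amine or a carboxylic acid carried on a longer chain there.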